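Amide nitrogen change from compound 2 to compound 3

The compounds below may be only part of what the source reports. "The series", "measured", "known", "first", "only" and "open" are said of these compounds alone.

Values in an ADME assay on HepG2 cells (Homo sapiens) for cytotoxicity, in the presence of a further agent that is not named here (on this read-out lower numbers stand for stronger inhibition and higher numbers for weaker inhibition), so far
compound 1 `Cn1c(Cc2ccccc2C(F)(F)F)nc(C(=O)NCc2cccnc2)c(O)c1=O` gives > 100000 nM as a limit
compound 2 `Cn1c(Cc2ccccc2C(F)(F)F)nc(C(=O)Nc2ccccc2)c(O)c1=O` gives > 100000 nM as a limit

Compound 2 stands only at > 100000 nM as a limit. Compound 3 `CC(NC(=O)c1nc(Cc2ccccc2C(F)(F)F)n(C)c(=O)c1O)c1ccccc1` differs from compound 2 by 1-phenylethyl in place of phenyl on an amide-type nitrogen with 1-phenylethyl in place of phenyl on an amide-type nitrogen. Among the compounds with values here, the one measured step is a step that the two limits leave unreadable from compound 1 to compound 2 and gives no size to carry over. No step beyond the scatter is expected in this assay because the limit of > 100000 nM in this assay, at which 2 of the 2 values shown sit, covers compound 1 and compound 2 alike. The expected step is estimated as a number no higher from compound 2 to compound 3 (the limit leaves the size open) in this series. Compound 3 is expected at 100000 nM with an estimated range from 40000 nM to 200000 nM for now.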

Compound 3, half-maximal inhibitory concentration: > 100000 nM
Compound 3 ended at the assay's limit (the forecaster's own chance of this, stated with the estimate: 85%); the middle value lies on the limit itself.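

No step can be read among compound 1, compound 2 and compound 3 in this assay, because all three sit at one limit: the limit of > 100000 nM in this assay, at which 3 of the 3 values shown sit.

The compounds shown leave open whether any group on the amide-type nitrogen would give a measurable value in this assay.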